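Removing a Methyl From Two Flavonoid Ether Compounds

The source may hold more compounds than are shown below. What is called first, only, known or untested is meant among the compounds shown, and "the series" means these compounds.

Compound 1 `C=C1CC[C@H]2C(C)(C)CCC[C@]2(C)[C@H]1CC/C(C)=C/Cc1c(O)cc(O)c2c(=O)c(O)c(-c3ccc(O)cc3)oc12` and compound 3 `C=C1CC[C@H]2C(C)(C)CCC[C@]2(C)[C@H]1CC/C(C)=C/Cc1c(O)cc(O)c2c(=O)c(O)c(-c3ccc(OC)cc3)oc12` share one core and differ in a single place: hydrogen in place of methyl on an oxygen on an aromatic ring. In a functional assay on A549 cells (Homo sapiens) for cytotoxicity, read by XTT assay, with a stated time of 72 h (on this read-out lower numbers stand for stronger inhibition and higher numbers for weaker inhibition), compound 1 gives 32000 nM. For compound 3 this assay reports only a limit, > 100000 nM. The change from the one to the other made a step of an at least 3.1-fold lower number from compound 3 to compound 1 (0.49 log units; beyond the scatter), a size that rests on (the limit of > 100000 nM in this assay, at which 2 of the 3 values shown sit).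

Compound 2 `C=C1CC[C@H]2C(C)(C)CCC[C@]2(C)[C@H]1CC/C(C)=C/COc1cc(O)c2c(=O)c(OC/C=C(\C)CC[C@H]3C(=C)CC[C@H]4C(C)(C)CCC[C@]34C)c(-c3ccc(OC)cc3)oc2c1` carries a different core, and how that core differs from the core of compound 3 is not broken down here. In this assay compound 2 also sits at a limit, > 100000 nM. Compound 4 `C=C1CC[C@H]2C(C)(C)CCC[C@]2(C)[C@H]1CC/C(C)=C/COc1cc(O)c2c(=O)c(OC/C=C(\C)CC[C@H]3C(=C)CC[C@H]4C(C)(C)CCC[C@]34C)c(-c3ccc(O)cc3)oc2c1` is not yet measured and differs from compound 2 by the same change: hydrogen in place of methyl on an oxygen on an aromatic ring.

The step expected from compound 2 to compound 4 is an at least 1.2-fold lower number from compound 2 to compound 4 (0.09 log units; that floor lies within the scatter), set beside the earlier step of an at least 3.1-fold lower number from compound 3 to compound 1 (0.49 log units; beyond the scatter), which comes from a single matched pair. Compound 4 is therefore expected to give 80000 nM, between 30000 nM and 300000 nM.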

Compound 4, half-maximal inhibitory concentration: > 100000 nM
Compound 4 gave a limit, no number; the forecaster's own chance of this, stated with the estimate: 55%; at least 1.2-fold (0.09 log units) between middle value and limit.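

Compound 2 and compound 4 both give only a limit in this assay, so no step between them can be read: the limit of > 100000 nM in this assay, at which 3 of the 4 values shown sit.

As far as these compounds go, whether methoxy to hydroxy lowers the number for compound 4, as it does for compound 1, stays open.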